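Oxygen Replaces Carbon in a Five-Membered Ring

This account rests on a few compounds, and the source may have more. Where it says the series, first, only, none or still open, it means among the compounds named here.

Compounds measured so far:
compound 1 `CCN1CCc2nc(C#Cc3ccccc3)sc2C1` — 1200 nM
compound 2 `O=C(C1CC1)N1CCc2nc(C#Cc3ccccc3)sc2C1` — 290 nM
compound 3 `O=C(C1CCCC1)N1CCc2nc(C#Cc3ccccc3)sc2C1` — > 10000 nM

In an assay on HEK293 cells for negative allosteric modulation of metabotropic glutamate receptor 5 (Homo sapiens), read by FLIPR, with a stated time of 1 h (on this read-out lower numbers stand for stronger inhibition and higher numbers for weaker inhibition), compound 1 gives 1200 nM and compound 2 gives 290 nM. For compound 3 this assay reports only a limit, > 10000 nM. Compound 3 therefore stands at the limit of > 10000 nM in this assay, at which 1 of the 3 values shown sits, the weakest point among the three, with no exact number of its own.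

The measured steps show a 4.1-fold lower number from compound 1 to compound 2 (0.62 log units; beyond the scatter), an at least 8.3-fold higher number from compound 1 to compound 3 (0.92 log units; beyond the scatter) and an at least 34-fold higher number from compound 2 to compound 3 (1.53 log units; beyond the scatter), so that enlarging the ring on the carbonyl carbon from cyclopropyl to cyclopentyl cost a great deal.

Compound 4 `O=C(C1CCCO1)N1CCc2nc(C#Cc3ccccc3)sc2C1` differs from compound 3 in that (oxolan-2-yl in place of cyclopentyl on a carbonyl carbon). The ring size is kept; one carbon of the five-membered ring becomes an oxygen. For the measured compounds named here, the steps that bear on this change are those to compound 3, which set its weak standing, yet none of them alters the ring's atoms rather than its size. He therefore expects at most a small gain, an at least 1.2-fold lower number from compound 3 to compound 4 (0.09 log units; that floor lies within the scatter), which may well leave compound 4 still at the limit. His estimate for compound 4 in this assay is 8000 nM, within 2500 nM to 30000 nM.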

Compound 4, half-maximal inhibitory concentration: > 10000 nM
Compound 4 ended at the assay's limit (the forecaster's own chance of this, stated with the estimate: 45%); at least 1.2-fold (0.09 log units) between middle value and limit.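

In this assay compound 4 gives > 10000 nM as a limit of the assay and not as a number. The step from compound 3 to compound 4 cannot be read, and the two compounds now share the same limit: the limit of > 10000 nM in this assay, at which 2 of the 4 values shown sit. Oxolan-2-yl on this carbonyl carbon, like cyclopentyl, falls far short of the smaller groups, with an at least 34-fold higher number from compound 2 to compound 4 (1.53 log units; beyond the scatter) and an at least 8.3-fold higher number from compound 1 to compound 4 (0.92 log units; beyond the scatter), so swapping a ring carbon for an oxygen, which adds one hydrogen-bond acceptor, does not recover what the five-membered ring lost.

From the compounds shown here alone, how far compound 3 and compound 4 lie beyond the limit stays open. Also open, going by these compounds, is whether cyclobutyl or oxetan-2-yl on this carbonyl carbon would hold the level of compound 2.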